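The source may report more compounds than this note shows. Statements on the series, on what has been measured and on what is new or still open speak of the compounds shown alone.

Measured in a functional assay on microsomes for inhibition, with a stated time of 1 h; on this read-out higher numbers stand for weaker inhibition and lower numbers for stronger inhibition:
compound 1 `COc1ccc(-c2nc(NN)n(C)c(=O)c2C#N)cc1`: 39 ug/mL
compound 2 `CCOC(=O)c1cnn(-c2nc(-c3ccccc3F)c(C#N)c(=O)n2C)c1N`: 94 ug/mL
compound 3 `CSc1nc(-c2cccs2)c(C#N)c(=O)n1C`: 83 ug/mL

Compound 2 gives 94 ug/mL, which cannot be told apart from compound 3 at 83 ug/mL, since the two lie within the usual scatter. Compound 1, at 39 ug/mL, has a lower number than compound 2, and that gap lies beyond the scatter. So compound 2 sits among the weaker inhibitors of this small set.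

Compound 4 `CCOC(=O)c1cnn(-c2nc(-c3ccc(N(C)C)cc3)c(C#N)c(=O)n2C)c1N` has not yet been measured. It differs from compound 2 in one place: 4-(dimethylamino)phenyl in place of 2-fluorophenyl on an aromatic carbon. In words, 4-(dimethylamino)phenyl stands in place of 2-fluorophenyl on an aromatic carbon.

Among the compounds with values here, no two measured compounds differ in only one place, so no measured step shows what such a change does. Within the data shown here, the only guide is the spread of the values, from compound 1 at 39 ug/mL to compound 2 at 94 ug/mL, and that spread is modest. No step beyond the scatter is therefore expected in this assay. The expected change is a 1.3-fold lower number from compound 2 to compound 4 (0.13 log units; within the scatter). For compound 4 the estimated value is 70 ug/mL, with an expected range from 30 ug/mL to 160 ug/mL.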

Compound 4, half-maximal inhibitory concentration: 111 ug/mL
For compound 4 the middle estimate is 1.6-fold (0.20 log units) below the measured one; the range from low to high includes it.
By their numbers in this assay, from the lowest: compound 1; then compounds 3, 2 and 4 (each within the scatter of the next).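

In this assay, putting 4-(dimethylamino)phenyl in place of 2-fluorophenyl on the aromatic carbon next to the ring nitrogen gives a 1.2-fold higher number from compound 2 to compound 4 (0.07 log units; within the scatter), so this first single-place comparison shows no difference that can be told from the scatter. At this position, ortho to a cyano group, a group with more heavy atoms and a hydrogen-bond acceptor therefore reads the same as one with neither feature. No measurement here accounts for this sameness.

Still open, from the compounds shown here alone, is whether any group at this position can move the number beyond the scatter, such as a carboxylic acid on the phenyl ring or a simple amine in place of that ring. Compound 1 gives 39 ug/mL but differs from compound 2 in more than one place, so it does not show which part of the structure matters.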